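The source may hold more compounds than are shown below. What is called first, only, known or untested is meant among the compounds shown, and "the series" means these compounds.

Compound 1 `CC(=O)N[C@@H](CSC(=O)Nc1ccccc1)C(=O)O` gives 178000 nM
Compound 2 `CC(=O)N[C@@H](CSC(=O)Nc1ccc(I)cc1)C(=O)O` gives only a limit of the assay > 200000 nM

In a functional assay on GC3/C1 cells (Homo sapiens) for cytotoxicity, read by MTT assay, with a stated time of 6 days (a higher number here means a weaker inhibitor, a lower number a stronger inhibitor), compound 1 gives 178000 nM as a true number. Compound 2 stands at the limit of > 200000 nM in this assay, at which 1 of the 2 values shown sits, and has no number of its own. The step followed here leads to compound 3 `CC(=O)N[C@@H](CSC(=O)Nc1ccc(Cl)cc1)C(=O)O` with the change chloro in place of iodo on an aromatic carbon and so puts chloro in place of iodo on an aromatic carbon. For the measured compounds named here, only one measured step bears on this place, the one with iodo in place of hydrogen on an aromatic carbon, and it shows an at least 1.1-fold higher number from compound 1 to compound 2 (0.05 log units; that floor lies within the scatter) and so gives no sign of a real gap. No step beyond the scatter is therefore expected in this assay and no direction is firm. Going by the values given here, compound 1 at 178000 nM offers the one true number to lean on, so the expectation stays close to it. The estimated step is an at least 1.1-fold lower number from compound 2 to compound 3 (0.07 log units; that floor lies within the scatter) and it is expected to stay small. The estimate for compound 3 is 170000 nM with an expected range of 90000 nM to 300000 nM in this measurement.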

Compound 3, half-maximal inhibitory concentration: 8130 nM
Beside the measured number, compound 3's estimate is 21-fold (1.32 log units) above it; the whole stated range lies above it.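

In this assay, the aromatic carbon para to a large group proves far more sensitive to what stands on it than the earlier pair suggested: chloro in place of hydrogen gives a 22-fold lower number from compound 1 to compound 3 (1.34 log units; beyond the scatter). Chloro in place of iodo gives an at least 24-fold lower number from compound 2 to compound 3 (1.39 log units; beyond the scatter), so the two halogens part widely at this one place, and a halogen there does not by itself bring the lower number, as compound 2 goes against any such rule. Compound 2 has only a limit of the assay and no number of its own, so this second step is a floor and its true size stays unknown: the limit of > 200000 nM in this assay, at which 1 of the 3 values shown sits.

The compounds shown leave open whether the lower number in this assay belongs to chloro alone or also appears with other groups at this place, such as fluoro, bromo or methyl. They also leave open whether it survives when the carboxylic acid of the shared core gives way to a methyl ester.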